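The compounds below may be only part of what the source reports. "The series", "measured", "known", "first", "only" and "open" are said of these compounds alone.

Compounds measured in a functional assay on OVCAR-3 cells (Homo sapiens) for cytotoxicity, read by sulforhodamine B assay; on this read-out lower numbers stand for higher toxicity in this test and higher numbers for lower toxicity in this test:

compound 1, `CC1=CC[C@@H]([C@@](C)(O)CCCC(C)(C)NC(=S)NN)CC1`, a limit of this assay: > 100000 nM.
compound 2, `CC1=CC[C@@H]([C@@](C)(O)CCCC(C)(C)NC(=S)N/N=C\c2ccccc2)CC1`: 43600 nM.
compound 3, `CC1=CC[C@@H]([C@@](C)(O)CCCC(C)(C)NC(=S)N/N=C\c2ccccc2[N+](=O)[O-])CC1`: 41900 nM.

The value of compound 1 is a limit of this assay, not a number, (the limit of > 100000 nM in this assay, at which 1 of the 3 values shown sits). Compound 3 gives the lowest of the two numbers shown; its nearest neighbour is compound 2, and the two lie within the scatter of each other, so no order between them can be claimed.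

The unmeasured compound 4 is `CC1=CC[C@@H]([C@@](C)(O)CCCC(C)(C)NC(=S)N/N=C\c2ccccc2Cl)CC1`. It differs from compound 3 as follows: chloro in place of nitro on an aromatic carbon. Among the measured compounds shown here, the step that bears most directly on this is the one from compound 2 to compound 3, which introduced the nitro at the same aromatic carbon: a 1.0-fold lower number from compound 2 to compound 3 (0.02 log units; within the scatter). The step from compound 1 to compound 2, an at least 2.2-fold lower number from compound 1 to compound 2 (0.36 log units; beyond the scatter), concerns the hydrazone portion as a whole and speaks only to the presence of the aromatic ring, not to its substituent. Since a nitro at this carbon left the number within the scatter, a chloro there is expected to do the same, with no step beyond the scatter in either direction: a 1.0-fold lower number from compound 3 to compound 4 (0.02 log units; within the scatter).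

Compound 4 is therefore estimated at 40000 nM in this assay, with a range from 20000 nM to 80000 nM.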

Compound 4, concentration lethal to 50% of the cells: > 100000 nM
Compound 4: only a limit was reported; the forecaster's own chance of this, stated with the estimate: 10%; middle value at least 2.5-fold (0.39 log units) from the limit.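

At this aromatic carbon, ortho to a large group, chloro in place of nitro gives an at least 2.3-fold higher number from compound 3 to compound 4 (0.37 log units; beyond the scatter) in this assay, and chloro in place of hydrogen gives an at least 2.2-fold higher number from compound 2 to compound 4 (0.36 log units; beyond the scatter). Nitro in place of hydrogen at the same carbon had stayed within the scatter, with a 1.0-fold lower number from compound 2 to compound 3 (0.02 log units; within the scatter), so the earlier compounds gave no sign that the substituent here could matter; the series now shows that it can, and that the hydrazone aromatic ring alone does not secure a number below the limit of the test. Compound 4 carries a limit and not a number, so both new steps give only a minimum size: the limit of > 100000 nM in this assay, at which 2 of the 4 values shown sit.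

From the compounds shown here alone, the step between the two limits, from compound 1 to compound 4, cannot be read, and how far compound 4 lies beyond its limit remains unknown. Going by these compounds, it also remains open whether chloro stands alone among substituents at this carbon or whether a fluoro, a bromo, a methoxy or an amine there would likewise move the value out of the range shared by compound 2 and compound 3.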